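The compounds below may be only part of what the source reports. "The series", "measured", "known", "first", "only" and "open" are said of these compounds alone.

Compound 1 `O=S(=O)(Nc1ccc2oc(-c3ccccc3)nc2c1)c1ccccc1O` gives 85000 nM in an assay on cells for inhibition of HSP60/HSP10 (Homo sapiens), with a stated time of 60 min; on this read-out lower numbers stand for stronger inhibition and higher numbers for weaker inhibition.
Compound 2 `O=S(=O)(Nc1ccc(-c2nc3cc(NS(=O)(=O)c4ccccc4O)ccc3o2)cc1)c1ccccc1O` gives 18000 nM in this assay.

On these numbers compound 1 stands highest of the two; its nearest neighbour is compound 2, reached by a 4.7-fold lower number from compound 1 to compound 2 (0.67 log units; beyond the scatter). Compound 3 `CS(=O)(=O)Nc1ccc2oc(-c3ccccc3)nc2c1` differs from compound 1 in one place: methyl in place of 2-hydroxyphenyl on a sulfonyl sulfur. For the measured compounds named here, the single measured step adds a second ((2-hydroxyphenyl)sulfonyl)amino group on an aromatic carbon and leaves the sulfonyl substituent untouched, so it does not bear on this change. Both measured compounds carry the 2-hydroxyphenyl on the sulfonyl sulfur, and nothing shows what follows when it is exchanged for methyl. Compound 1 is already a weak inhibitor, and the change removes that ring. Compound 3 is therefore expected to give 150000 nM in this assay, between 40000 nM and 500000 nM. The step of a 1.8-fold higher number from compound 1 to compound 3 (0.25 log units; within the scatter) is expected to be a modest rise in the number, possibly ending as a limit.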

Compound 3, half-maximal inhibitory concentration: > 100000 nM
Compound 3: a limit, no number (the forecaster's own chance of this, stated with the estimate: 40%); the middle value does not contradict the limit.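

Methyl on the sulfonyl sulfur gives no stronger inhibition than the 2-hydroxyphenyl of compound 1 in this assay, and the change reads as an at least 1.1-fold higher number from compound 1 to compound 3 (0.07 log units; that floor lies within the scatter). For the compounds shown here, the floor of that step lies within the scatter, so the true size of the rise stays unknown, and the earlier compounds, which both carried the 2-hydroxyphenyl there, could show nothing about this exchange. Compound 3 gives a limit of the assay and not a number: the limit of > 100000 nM in this assay, at which 1 of the 3 values shown sits.

From the compounds shown here alone, what a plain phenyl or a 2-methoxyphenyl on the sulfonyl sulfur would give remains open, and so does whether the ring, its hydroxyl or neither matters at this position. Also open, going by these compounds, is what methyl in place of 2-hydroxyphenyl would do in compound 2.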